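From 2-ethylphenyl to 3-methylphenyl on a shared core

The compounds below may be only part of what the source reports. "The series", "measured", "known", "first", "only" and "open" are said of these compounds alone.

Going by the values given here, in a functional assay (muscle tissue) with Cavia porcellus as the target (a lower number here means that less compound is needed, a higher number that more compound is needed for the effect), compound 3 `CCc1ccccc1C1C(C(=O)OC)=C(C)N=C(C)/C1=C(\O)OC` gives 6.46 nM, the lowest number of the three measured so far. Compound 2 `COC(=O)C1=C(C)N=C(C)/C(=C(\O)OC)C1c1ccccc1I` gives 46.8 nM, and compound 1 `COC(=O)C1=C(C)N=C(C)/C(=C(\O)OC)C1c1ccc(F)cc1` gives 129 nM.

Compound 4 `COC(=O)C1=C(C)N=C(C)/C(=C(\O)OC)C1c1cccc(C)c1` keeps the shared core and changes one group: 3-methylphenyl in place of 2-ethylphenyl on a saturated ring carbon, (3-methylphenyl in place of 2-ethylphenyl on a saturated ring carbon).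

The three measured steps all change this same group. The largest is a 20-fold lower number from compound 1 to compound 3 (1.30 log units; beyond the scatter). The other two are modest: a 7.2-fold lower number from compound 2 to compound 3 (0.86 log units; beyond the scatter), and a 2.8-fold lower number from compound 1 to compound 2 (0.44 log units; beyond the scatter). So both measured compounds without the 2-ethylphenyl group sit higher than compound 3, which makes a rise in this assay the likely direction on leaving it. Among the compounds with values here, no measured compound carries 3-methylphenyl, so these steps are only a rough guide to the size of the change. A modest rise, close to the size of the step between compound 2 and compound 3, seems the fairest reading.

The expected step is a 5.4-fold higher number from compound 3 to compound 4 (0.73 log units; beyond the scatter). For compound 4 the estimated value is 35 nM, with an expected range from 10 nM to 130 nM.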

Compound 4, half-maximal effective concentration: 110 nM
Beside the measured number, compound 4's estimate is 3.1-fold (0.50 log units) below it; low and high end bracket the measured number.
By their numbers in this assay, from the lowest: compound 3; then compound 2; then compounds 4 and 1 (each within the scatter of the next).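

The alkyl group on the phenyl ring does not by itself keep the number low: in this assay, 3-methylphenyl in place of 2-ethylphenyl gives a 17-fold higher number from compound 3 to compound 4 (1.23 log units; beyond the scatter), one of the largest steps in the series. The new compound also sits on the higher side of 2-iodophenyl, with a 2.4-fold higher number from compound 2 to compound 4 (0.37 log units; beyond the scatter), while a 1.2-fold lower number from compound 1 to compound 4 (0.07 log units; within the scatter) lies within the usual scatter, so 3-methylphenyl and 4-fluorophenyl cannot be told apart here. Among these four compounds, then, the two lowest numbers belong to the groups named 2-ethylphenyl and 2-iodophenyl, and no compound shown goes against that pattern, though four compounds make only a thin basis for it.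

The change to compound 4 alters both the length of the chain and its place on the phenyl ring, so the compounds shown cannot separate the two, and a 2-methylphenyl or a 3-ethylphenyl group would be needed to pull them apart. Why these groups differ also stays open, as no measurement shown here bears on the cause.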